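Thiophen-3-yl in place of furan-2-yl on the saturated ring carbon

This account rests on a few compounds, and the source may have more. Where it says the series, first, only, none or still open, it means among the compounds named here.

Compound 1 `CC1=C(C(N)=O)C(c2ccsc2)NC(=O)N1`: 1%
Compound 2 `CC1=C(C(=O)NC(C)C)C(c2ccsc2)NC(=O)N1`: 1%
Compound 3 `CCC(C)OC(=O)C1=C(C)NC(=O)NC1c1ccco1`: 3%

Of the compounds shown here, three have been measured in an assay on membranes from HeLa cells for displacement of a labelled ligand from adenosine receptor A3 (Homo sapiens), read by scintillation counting, with a stated time of 180 min, tested at 1 uM; a lower number here means less inhibition, a higher number more inhibition at the concentration tested (going by the name of the read-out). Compound 3 holds the highest of the three numbers, but its gap to compound 1 and its gap to compound 2 both lie within the scatter, so no order among the three can be read from them; all three sit close to zero. Among the compounds with values here, the single measured step, no change at the digits printed from compound 1 to compound 2 (within the scatter), concerns an isopropyl in place of hydrogen on an amide-type nitrogen, a site that is not touched here, so it bears on the present change only in showing that this series has so far not moved at the digits.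

Compound 4 `CCC(C)OC(=O)C1=C(C)NC(=O)NC1c1ccsc1` differs from compound 3 by thiophen-3-yl in place of furan-2-yl on a saturated ring carbon. Compound 1 and compound 2 already carry thiophen-3-yl on that saturated ring carbon and read as low as compound 3 does with furan-2-yl, so compound 4 is expected to show no step beyond the scatter, no change at the digits printed from compound 3 to compound 4 (within the scatter). Compound 4 is therefore estimated at 3%, with a range from -6% to 12%.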

Compound 4, a percentage reported as inhibition, at one concentration (the size of the read-out at that concentration, not a potency): 7%
Compound 4: the middle estimate sits 4 percentage points below what was measured, within the range that was stated.
By their numbers in this assay, from the lowest: compounds 1, 2, 3 and 4 (each within the scatter of the next).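

In this assay, within the data shown here, thiophen-3-yl in place of furan-2-yl on the saturated ring carbon gives a number 4 percentage points higher from compound 3 to compound 4 (within the scatter), the first direct reading at this position, and with the sec-butoxy carbonyl held constant the two five-membered aromatic rings cannot be told apart. Among these compounds, the result also gives the first reading at the carbonyl carbon with thiophen-3-yl held constant: sec-butoxy in place of isopropylamino gives a number 6 percentage points higher from compound 2 to compound 4 (within the scatter), and sec-butoxy in place of amino gives a number 6 percentage points higher from compound 1 to compound 4 (within the scatter), so neither exchange separates the compounds in this assay. No available evidence offers an explanation for these readings.

Since all four compounds lie within the scatter of one another, the data do not show whether either site can influence the read-out in this assay at all. Going by these compounds, it remains open whether a phenyl or a pyridyl ring on the saturated ring carbon, or a carboxylic acid or a longer alkoxy chain on the carbonyl carbon, would give a step beyond the scatter.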